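Three Esters and Sulfonates Sitting at the Assay Limit

This account rests on a few compounds, and the source may have more. Where it says the series, first, only, none or still open, it means among the compounds named here.

Compound 1 `CCCC(=O)OC1CCC(CN2CCN(c3cc(=O)c4cc(C(F)(F)F)cc([N+](=O)[O-])c4s3)CC2)CC1`: > 64 ug/mL
Compound 2 `CC(C)S(=O)(=O)OC1CCC(CN2CCN(c3cc(=O)c4cc(C(F)(F)F)cc([N+](=O)[O-])c4s3)CC2)CC1`: > 64 ug/mL
Compound 3 `O=c1cc(N2CCN(CC3CCC(OS(=O)(=O)c4ccc5ccccc5c4)CC3)CC2)sc2c([N+](=O)[O-])cc(C(F)(F)F)cc12`: > 64 ug/mL

All three measured compounds share one core and differ only in the group attached to the oxygen on the saturated ring carbon. In an ADME assay on Vero cells (Chlorocebus sabaeus) for cytotoxicity, read by MTT assay, with a stated time of 48 h (a higher number here means a weaker inhibitor, a lower number a stronger inhibitor), compound 1 reaches only a limit, > 64 ug/mL. Compound 2 likewise gives a limit, > 64 ug/mL. Compound 3 also stops at a limit, > 64 ug/mL. Because of the limit of > 64 ug/mL in this assay, at which 3 of the 3 values shown sit, none of the steps can be sized: a step that the two limits leave unreadable from compound 1 to compound 2, and a step that the two limits leave unreadable from compound 2 to compound 3.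

Compound 2 therefore stands at the limit, with no numerical value of its own; the other two values shown are limits as well.

Compound 4 `O=C(OC1CCC(CN2CCN(c3cc(=O)c4cc(C(F)(F)F)cc([N+](=O)[O-])c4s3)CC2)CC1)c1ccc2ccccc2c1` is the next compound to be measured. ((naphthalen-2-yl)carbonyl in place of isopropylsulfonyl on an oxygen on a saturated carbon). The change echoes the move from compound 2 to compound 3, where a naphthalen-2-yl group entered on a sulfonyl sulfur and the result stayed at the limit, and the ester-to-sulfonate swap from compound 1 to compound 2 stayed there too.

For the measured compounds named here, since no measured step shows movement, no step beyond the scatter is expected in this assay, and compound 4 is expected to remain at or near the limit: a step that the limit leaves unreadable from compound 2 to compound 4. The estimate for compound 4 is 80 ug/mL, with a range from 40 ug/mL to 200 ug/mL.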

Compound 4, half-maximal inhibitory concentration: > 64 ug/mL
Compound 4 gave a limit, no number (the forecaster's own chance of this, stated with the estimate: 80%); the middle value does not contradict the limit.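

No new step can be read for compound 4 against compound 1 or compound 2, because these values are limits and not numbers: the limit of > 64 ug/mL in this assay, at which 4 of the 4 values shown sit.

The compounds shown leave open whether changing the group on the oxygen affects the half-maximal inhibitory concentration in this assay at all, and what that concentration is for any of them.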